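Sulfonamide aryl variation in a thromboxane receptor antagonist series

This account rests on a few compounds, and the source may have more. Where it says the series, first, only, none or still open, it means among the compounds named here.

Measured compounds:
- compound 1, `O=C(O)CCCCCC[C@@H]1[C@@H](CNS(=O)(=O)c2ccc(F)cc2)CC[C@H]1F`: 6000 nM
- compound 2, `O=C(O)CC/C=C\CC1=CCC[C@@H]1NS(=O)(=O)c1ccccc1`: 2200 nM
- compound 3, `O=C(O)CCC/C=C\C[C@H]1[C@H](F)CC[C@@H]1NS(=O)(=O)c1ccccc1`: 1100 nM

All three were run in a functional assay on a cell-free system (plasma) for inhibition of thromboxane A2 receptor (Homo sapiens), read by turbidimetry; on this read-out higher numbers stand for weaker inhibition and lower numbers for stronger inhibition. Compound 3 gives the lowest number of the three, at 1100 nM. Its gap to compound 2, at 2200 nM, is within the scatter of the method, so the two cannot be ranked against each other. Its gap to compound 1, at 6000 nM, is beyond the scatter, and compound 3 is the stronger inhibitor of that pair.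

The next compound, compound 4, `O=C(O)CCC/C=C\C[C@H]1[C@H](F)CC[C@@H]1NS(=O)(=O)c1ccc(Cl)c(Cl)c1`, keeps the whole of compound 3 apart from the aryl on the sulfonyl sulfur: 3,4-dichlorophenyl in place of phenyl on a sulfonyl sulfur

For the measured compounds named here, no pair of measured compounds differs in one place only, so there is no measured step to lean on for this change. The expectation is nonetheless a step toward stronger inhibition of modest size, expected to come out as a 2.4-fold lower number from compound 3 to compound 4 (0.39 log units; beyond the scatter) in this assay, with the chance that it ends up within the scatter not excluded. On that basis compound 4 is estimated at 450 nM in this assay, with a plausible range from 120 nM to 2000 nM.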

Compound 4, half-maximal inhibitory concentration: 630 nM
The estimate for compound 4 lay 1.4-fold (0.15 log units) below the measured number, within the range that was stated.
By their numbers in this assay, from the lowest: compounds 4, 3 and 2 (each within the scatter of the next, the first and the last beyond it); then compound 1.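

In this assay, for the compounds shown here, this is the first measured step at the aryl on the sulfonyl sulfur: a 1.7-fold lower number from compound 3 to compound 4 (0.24 log units; within the scatter). Placing 3,4-dichlorophenyl on the sulfonyl sulfur in place of phenyl therefore leaves compound 4 and compound 3 unranked on this read-out, and the chlorine atoms bring no change that can be separated from the scatter. The position accepts this aryl without a loss beyond the scatter, but the data neither confirm nor exclude a small real gain, and no measurement available here bears on the reason for this result.

One replacement on one core cannot show whether the read-out responds to the aryl on the sulfonyl sulfur at all, nor whether the same replacement would behave alike on the core of compound 1 or compound 2. A naphthyl group, a pyridyl ring or a methyl group on the sulfonyl sulfur would test whether this position allows a step beyond the scatter in either direction.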